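Permeability notes on a bicyclic diamine series: toward compound 4

A few compounds are considered here, and "the series" means these few. Any claim that something is new, unique, unknown or untested is made for them only; others in the source may bear on it.

compound 1 `NCCCCN(C[C@H]1Cc2ncccc2CN1)[C@H]1CCCc2cccnc21` — 17 nm/s
compound 2 `NC/C=C\CN(C[C@H]1Cc2ncccc2CN1)[C@H]1CCCc2cccnc21` — 28 nm/s
compound 3 `NC(=O)NCCCCN(C[C@H]1Cc2ncccc2CN1)[C@H]1CCCc2cccnc21` — 7 nm/s

In an ADME assay for permeability, using PAMPA, with a stated time of 4 h, at pH 5.5 (on this read-out lower numbers stand for lower permeability and higher numbers for higher permeability), compound 2 holds the highest of the three numbers. The step of a 1.6-fold higher number from compound 1 to compound 2 (0.22 log units; within the scatter) stays within the scatter, while a 4.0-fold lower number from compound 2 to compound 3 (0.60 log units; beyond the scatter) and a 2.4-fold lower number from compound 1 to compound 3 (0.39 log units; beyond the scatter) lie beyond it.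

Compound 4 `CN(CCCCN(C[C@H]1Cc2ncccc2CN1)[C@H]1CCCc2cccnc21)C1CCOCC1` differs from compound 2 by a group of 11 heavy atoms (9 carbon, 1 nitrogen, 1 oxygen; one six-membered non-aromatic ring with 1 hetero atom) in place of a group of 4 heavy atoms (3 carbon, 1 nitrogen; no ring), on a saturated chain carbon bound to an amine nitrogen. Among the compounds with values here, no measured step makes this exchange; the nearest is a 4.0-fold lower number from compound 2 to compound 3 (0.60 log units; beyond the scatter), in which a change at the same chain end lowered the number. The present change is of a different kind, so a step of modest size in the upward direction is expected, a 2.1-fold higher number from compound 2 to compound 4 (0.33 log units; beyond the scatter), with real uncertainty. Compound 4 is estimated at 60 nm/s, expected between 20 nm/s and 180 nm/s in this assay.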

Compound 4, apparent permeability: 15 nm/s
Compound 4: the middle estimate sits 4.0-fold (0.60 log units) above what was measured, outside the stated range (below it).
By their numbers in this assay, from the lowest: compound 3; then compounds 4, 1 and 2 (each within the scatter of the next).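

At this chain end, in this assay, methyl(oxan-4-yl)amino gives a 1.1-fold lower number from compound 1 to compound 4 (0.05 log units; within the scatter) against amino and a 1.9-fold lower number from compound 2 to compound 4 (0.27 log units; within the scatter) against 3-aminoprop-1-en-1-yl, so a group of 11 heavy atoms with a six-membered ring stays within the scatter of both smaller primary amine groups. Only the ureido group stands apart here, with a 2.1-fold higher number from compound 3 to compound 4 (0.33 log units; beyond the scatter) and a clear gap to the amine-ended compounds. No measurement at hand gives a reason for this.

Open, going by these compounds, is whether a carboxylic acid at the same chain end would give a number near compound 3 or near compound 1. Also open, on these data alone, is what oxan-4-ylamino, without the methyl, would give.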